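The compounds below may be only part of what the source reports. "The series", "measured", "known", "first", "only" and "open" are said of these compounds alone.

Compound 1, `O=C(CCc1cccc2c1B(O)OC2)NC1CCCCC1`, is one of three compounds of a shared core that have been examined in an ADME assay on WI-38 cells (Homo sapiens) for cytotoxicity, read by MTT assay, with a stated time of 72 h (a lower number here means a stronger inhibitor, a higher number a weaker inhibitor), and in that test compound 1 gives > 100000 nM, which is a limit of the assay rather than a measured number. The companion compound 2, `C#Cc1ccc(NC(=O)CCc2cccc3c2B(O)OC3)cc1`, gives > 100000 nM in this assay, again a limit. Compound 3, `COc1ccc(NC(=O)CCc2cccc3c2B(O)OC3)cc1`, likewise gives > 100000 nM in this assay, a limit as well. Among the measured compounds shown here, the only one-place change among the measured compounds is methoxy in place of ethynyl on an aromatic carbon, and that step, a step that the two limits leave unreadable from compound 2 to compound 3, cannot be read because of the limit of > 100000 nM in this assay, at which 3 of the 3 values shown sit.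

Compound 4, `O=C(CCc1cccc2c1B(O)OC2)Nc1cccc(Br)c1`, has not yet been measured. It differs from compound 1 in a single place: 3-bromophenyl in place of cyclohexyl on an amide-type nitrogen. For the measured compounds named here, no measured step touches the amide-type nitrogen, so nothing bears directly on this change; what is known is only that all three compounds so far sit at the same limit. Compound 4 is therefore expected to behave like the others, with a step that the limit leaves unreadable from compound 1 to compound 4 that is estimated as nothing beyond the scatter, and most likely the assay will again return only a limit. Compound 4 is expected to give about 150000 nM, within a range of 50000 nM to 500000 nM.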

Compound 4, half-maximal inhibitory concentration: 20000 nM
Estimate against measurement, compound 4: 7.5-fold (0.88 log units) above; measured number below the stated range.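

In this assay, 3-bromophenyl in place of cyclohexyl on an amide-type nitrogen gives an at least 5.0-fold lower number from compound 1 to compound 4 (0.69 log units; beyond the scatter), so a change at this position can bring the read-out within the range of the assay. Compound 4 is the only compound shown that gives a measured number, 20000 nM, so this nitrogen is the one place where the series has so far yielded a readable step, and that step points towards more cytotoxicity in these cells. The true size of the step remains unknown, and only its lower bound can be stated, because compound 1 sits at a limit of the assay: the limit of > 100000 nM in this assay, at which 3 of the 4 values shown sit.

The compounds shown leave open whether this step belongs to the aromatic ring as a whole or to the bromine it carries, and an unsubstituted phenyl on the same nitrogen would separate the two. They also leave open whether the bromine itself is needed, which 3-chlorophenyl or 3-methylphenyl in its place would test, and whether a carboxylic acid or an amine on that ring would return the read-out to the limit.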